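The source may hold more compounds than are shown below. What is called first, only, known or untested is meant among the compounds shown, and "the series" means these compounds.

Measured so far:
Compound 1, `Fc1ccc(-c2cn3ccnc3c(-c3ccc4ncn(C5CCCCC5)c4c3)n2)cc1`: 7.94%
Compound 2, `Brc1ccc(-c2cn3ccnc3c(-c3ccc4ncn(C5CCCCC5)c4c3)n2)cc1`: 23.7%

Both compounds were tested in a functional assay on U-251 cells (Homo sapiens) for inhibition, read by sulforhodamine B assay, with a stated time of 48 h, tested at 10 uM; a higher number here means more inhibition at the concentration tested (going by the name of the read-out), a lower number less inhibition. Going by the values given here, compound 2 stands highest of the two numbers; its nearest neighbour is compound 1, and the single measured step, a number 15.8 percentage points higher from compound 1 to compound 2 (beyond the scatter), lies beyond the scatter. That is all the numerical ground there is.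

Compound 3, `c1csc(-c2cn3ccnc3c(-c3ccc4ncn(C5CCCCC5)c4c3)n2)c1`, differs from compound 2 in one place: thiophen-2-yl in place of 4-bromophenyl on an aromatic carbon. Among the compounds with values here, the only measured step, bromo in place of fluoro on an aromatic carbon, bears on the same position but not on the same kind of change, since here the whole six-membered ring gives way to a five-membered one and the bromine departs with it. What that step does show is that alterations at this position can move this assay by a modest amount. With the bromine gone, compound 3 is expected to sit closer to compound 1 than to compound 2, so the step of a number 11.7 percentage points lower from compound 2 to compound 3 (beyond the scatter) is expected to be downward and modest. Compound 3 is therefore estimated at 12%, within a range from 0% to 35%.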

Compound 3, a percentage reported as inhibition, at one concentration (the size of the read-out at that concentration, not a potency): 3.92%
The estimate for compound 3 lay 8.1 percentage points above the measured number; the range from low to high includes it.
By their numbers in this assay, from the lowest: compounds 3 and 1 (each within the scatter of the next); then compound 2.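

In this assay, thiophen-2-yl in place of 4-bromophenyl on an aromatic carbon gives a number 19.8 percentage points lower from compound 2 to compound 3 (beyond the scatter) and so takes away the advantage that compound 2 held at this position. Thiophen-2-yl in place of 4-fluorophenyl gives a number 4 percentage points lower from compound 1 to compound 3 (within the scatter) and so separates compound 3 from neither fluorinated compound 1 nor its level, which means that a five-membered aromatic ring with 1 hetero atom can replace the 4-fluorophenyl group here with no change that can be read, while among these three groups only 4-bromophenyl stands apart. Nothing available explains why compound 2 stands apart from the other two compounds, and the inhibition of compound 2 is itself only 23.7% at the single concentration tested.

The compounds shown leave open whether the higher number of compound 2 belongs to the bromine itself or would also appear with a 4-chlorophenyl or 4-iodophenyl group, or with an unsubstituted phenyl as the reference point. They also leave open how this position in this assay would respond to a group of another kind, such as an amine or a carboxylic acid on the phenyl ring.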